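Para-Hydroxyphenyl Analogue of a Triazole-Linked Bicyclic Lactam

The source may hold more compounds than are shown below. What is called first, only, known or untested is meant among the compounds shown, and "the series" means these compounds.

Measured compounds:
compound 1 `CC1(C)[C@H]2CC[C@]1(C)N(Cc1cn(-c3cccc(Cl)c3)nn1)C(=O)C2` — 60 nM
compound 2 `Cc1ccc(-n2cc(CN3C(=O)C[C@@H]4CC[C@@]3(C)C4(C)C)nn2)cc1` — 400 nM
compound 3 `CC1(C)[C@H]2CC[C@]1(C)N(Cc1cn(-c3ccc(Br)cc3)nn1)C(=O)C2` — 80 nM

In a functional assay on A549 cells (Homo sapiens) for inhibition, read by MTT assay, with a stated time of 24 h (on this read-out lower numbers stand for stronger inhibition and higher numbers for weaker inhibition), compound 3 stands second highest of the three numbers; its nearest neighbour is compound 1, a 1.3-fold higher number from compound 1 to compound 3 (0.12 log units; within the scatter), and its furthest is compound 2, a 5.0-fold lower number from compound 2 to compound 3 (0.70 log units; beyond the scatter). Compound 4 `CC1(C)[C@H]2CC[C@]1(C)N(Cc1cn(-c3ccc(O)cc3)nn1)C(=O)C2` is the next member: hydroxy in place of bromo on an aromatic carbon. Among the measured compounds shown here, no measured step exchanges bromo for hydroxy, so the only guide is the step from compound 2 to compound 3, a 5.0-fold lower number from compound 2 to compound 3 (0.70 log units; beyond the scatter), which shows that a group on this aromatic carbon can shift this assay by a modest amount in either direction. A modest rise is therefore expected, a 2.5-fold higher number from compound 3 to compound 4 (0.40 log units; beyond the scatter), with wide uncertainty. Compound 4 is estimated at 200 nM, in a range from 60 nM to 700 nM.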

Compound 4, half-maximal inhibitory concentration: 140 nM
Estimate against measurement, compound 4: 1.4-fold (0.15 log units) above; the range from low to high includes it.
By their numbers in this assay, from the lowest: compounds 1, 3 and 4 (each within the scatter of the next, the first and the last beyond it); then compound 2.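

In this assay, hydroxy in place of bromo on this aromatic carbon, para to a large group, gives a 1.8-fold higher number from compound 3 to compound 4 (0.24 log units; within the scatter), so this exchange adds a hydrogen-bond donor without a change beyond the scatter. Hydroxy also stands apart from methyl, with a 2.9-fold lower number from compound 2 to compound 4 (0.46 log units; beyond the scatter), leaving compound 2 as the weakest of the four. Yet a 2.3-fold higher number from compound 1 to compound 4 (0.37 log units; beyond the scatter) separates compound 4 from compound 1, a gap that compound 3 does not show. No measured evidence accounts for these steps.

From the compounds shown here alone, whether an amine, a methoxy group or a carboxylic acid on this aromatic carbon would match hydroxy or bromo remains open.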